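A few compounds are considered here, and "the series" means these few. Any claim that something is new, unique, unknown or untested is made for them only; others in the source may bear on it.

Measured so far in an ADME assay on MT4 cells (Homo sapiens) for cytotoxicity (on this read-out lower numbers stand for higher toxicity in this test and higher numbers for lower toxicity in this test), each value being a limit and not a number:

- compound 1 `COC(=O)N[C@H](C(=O)NN(CCC[C@@](O)(Cc1ccccc1)C(=O)N[C@H]1c2ccccc2C[C@H]1O)Cc1ccc(-c2nc(C(C)(C)C)cs2)cc1)C(C)(C)C`: > 10000 nM
- compound 2 `COC(=O)N[C@H](C(=O)NN(CCC[C@@](O)(Cc1ccccc1)C(=O)N[C@H]1c2ccccc2C[C@H]1O)Cc1ccc(-c2cn3ccsc3n2)cc1)C(C)(C)C`: > 10000 nM
- compound 3 `COC(=O)N[C@H](C(=O)NN(CCC[C@@](O)(Cc1ccccc1)C(=O)N[C@H]1c2ccccc2C[C@H]1O)Cc1ccc(-c2ccncc2)cc1)C(C)(C)C`: > 10000 nM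

Compound 3 has no number in this assay. It shares its position with the other two compounds, namely (the limit of > 10000 nM in this assay, at which 3 of the 3 values shown sit). The series therefore offers no toxic reference point and no ranking.

The next change leads to compound 4 `COC(=O)N[C@H](C(=O)NN(CCC[C@@](O)(Cc1ccccc1)C(=O)N[C@H]1c2ccccc2C[C@H]1O)Cc1ccc(-c2ccsc2)cc1)C(C)(C)C`, with thiophen-3-yl in place of pyridin-4-yl on an aromatic carbon, para to a large group: thiophen-3-yl in place of pyridin-4-yl on an aromatic carbon.

Three measured steps change the group at this same place: a step that the two limits leave unreadable from compound 1 to compound 2, a step that the two limits leave unreadable from compound 1 to compound 3 and a step that the two limits leave unreadable from compound 2 to compound 3. None has a readable size, so they give no direction for the new exchange. For the measured compounds named here, they show only that three different groups at this place all left the read-out at the limit.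

On that basis, no change beyond the scatter is expected, and the most likely report is again a limit. The expected step is a step that the limit leaves unreadable from compound 3 to compound 4.

For compound 4 the estimated value is 14000 nM, with an expected range from 7000 nM to 30000 nM.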

Compound 4, half-maximal cytotoxic concentration: > 10000 nM
Compound 4 was reported as a limit; the forecaster's own chance of this, stated with the estimate: 85%; the middle value is on the limit's open side.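

In this assay compound 4 gives > 10000 nM, a limit and not a number. The steps from compound 1, compound 2 and compound 3 to compound 4 cannot be read, as all values share one position: the limit of > 10000 nM in this assay, at which 4 of the 4 values shown sit. The compounds shown leave open at what concentration any of them becomes cytotoxic, and whether the groups exchanged at this place differ at all.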